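Pyridyl swap on the shared core of compound 2

A few compounds are considered here, and "the series" means these few. Any claim that something is new, unique, unknown or untested is made for them only; others in the source may bear on it.

For the measured compounds named here, compound 2 `O=C(O)Cc1sc(C(c2ccc(F)cc2)c2ccc(F)cc2)nc1-c1ccnc(Cl)c1` gives 39 nM in an in vitro functional assay on HEK285-7 cells for antagonist activity at prostaglandin D2 receptor 2 (Homo sapiens), read by BRET and beta-arrestin recruitment (on this read-out lower numbers stand for stronger inhibition and higher numbers for weaker inhibition), the lowest of the two numbers measured so far; compound 1 `COc1cc(-c2nc(C(c3ccc(F)cc3)c3ccc(F)cc3)sc2CC(=O)O)ccn1` gives 380 nM. Going by the values given here, the single measured step, a 9.7-fold lower number from compound 1 to compound 2 (0.99 log units; beyond the scatter), shows that changing the group on this pyridyl ring moves the number well beyond the scatter. Compound 3 `Cc1cc(-c2nc(C(c3ccc(F)cc3)c3ccc(F)cc3)sc2CC(=O)O)cnc1N` differs from compound 2 by 6-amino-5-methylpyridin-3-yl in place of 2-chloropyridin-4-yl on an aromatic carbon. Among the compounds with values here, no measured step covers a change of this kind, though the one step does concern this same ring. A larger number is expected for compound 3, a 3.8-fold higher number from compound 2 to compound 3 (0.59 log units; beyond the scatter). The estimate for compound 3 is 150 nM, with a range from 40 nM to 600 nM.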

Compound 3, half-maximal inhibitory concentration: > 100000 nM
Compound 3 was reported as a limit (the forecaster's own chance of this, stated with the estimate: 5%); at least 660-fold (2.82 log units) between middle value and limit.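

In this assay compound 3 sits at a limit, not at a number: the limit of > 100000 nM in this assay, at which 1 of the 3 values shown sits. The group on this aromatic carbon can therefore do far more than the earlier, modest a 9.7-fold lower number from compound 1 to compound 2 (0.99 log units; beyond the scatter) suggested: 6-amino-5-methylpyridin-3-yl gives an at least 2500-fold higher number from compound 2 to compound 3 (3.40 log units; beyond the scatter) and also an at least 260-fold higher number from compound 1 to compound 3 (2.42 log units; beyond the scatter).

The swap changes the whole pyridyl group at once, so the shown compounds do not separate the contributions of the amino group, the methyl group and the ring linkage. As far as these compounds go, how 6-aminopyridin-3-yl without the methyl, or 5-methylpyridin-3-yl without the amine, would read remains open.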